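A few compounds are considered here, and "the series" means these few. Any claim that something is new, unique, unknown or untested is made for them only; others in the source may bear on it.

Working notes on the series.

Compound 1 `Cc1ccc(C2=NN(C3=NC(c4ccccc4)CS3)C(c3ccc4ccccc4c3)C2)cc1`, compound 2 `Brc1ccc(C2=NN(C3=NC(c4ccccc4)CS3)C(c3ccc4ccccc4c3)C2)cc1` and compound 3 `O=C1CSC(N2N=C(c3ccc(Br)cc3)CC2c2cccc3ccccc23)=N1` have been measured in a functional assay on BGC-823 cells (Homo sapiens) for inhibition, read by CCK-8 assay, with a stated time of 48 h; a lower number here means a stronger inhibitor, a higher number a weaker inhibitor. Compound 1 gives 8940 nM, compound 2 gives 13000 nM and compound 3 gives 14600 nM; all three values sit within the scatter of one another, so no order among them is claimed. Compound 2 and compound 1 differ in one place only, (methyl in place of bromo on an aromatic carbon), and the step of a 1.5-fold lower number from compound 2 to compound 1 (0.16 log units; within the scatter). How the core of compound 3 differs from that of compound 2 is not broken down here.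

Compound 4 `Cc1ccc(C2=NN(C3=NC(=O)CS3)C(c3cccc4ccccc34)C2)cc1` has not yet been measured in this assay. It stands to compound 3 as compound 1 stands to compound 2: methyl in place of bromo on an aromatic carbon, the same change at the same place. The expectation rests on that single precedent, the step of a 1.5-fold lower number from compound 2 to compound 1 (0.16 log units; within the scatter), which is small and within the scatter; the same kind of step is therefore expected from compound 3 to compound 4, a 1.5-fold lower number from compound 3 to compound 4 (0.16 log units; within the scatter). For compound 4 the estimated value in this assay is 10000 nM, expected to fall between 5000 nM and 22000 nM.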

Compound 4, half-maximal inhibitory concentration: 10000 nM
For compound 4 middle estimate and measured number coincide at the digits printed; the measured number falls inside the stated range.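

Read on a second core, methyl in place of bromo in this assay gives a 1.5-fold lower number from compound 3 to compound 4 (0.16 log units; within the scatter). The two readings of this change agree: the same change on two cores in this assay, a 1.5-fold lower number (0.16 log units; within the scatter) from compound 2 to compound 1 and a 1.5-fold lower number (0.16 log units; within the scatter) from compound 3 to compound 4, 1.0-fold (0.00 log units) apart, within the scatter of two such steps. On these two cores, then, the 4-bromophenyl to 4-methylphenyl change stays within the scatter each time, which shows that a step too small to read on one core remains too small to read on the other, but it does not show a real effect of the change that carries over, nor that the same would hold on any further core.

The compounds shown leave open whether a different group at the same place, such as an amine, a carboxylic acid or a longer chain, would give a step beyond the scatter on either core. As far as these compounds go, how the two cores compare also stays open, since the compounds on one core differ from those on the other in more than one place.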